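The compounds below may be only part of what the source reports. "The series", "measured", "known", "first", "only" and "open" are said of these compounds alone.

Measured compounds:
compound 1 `CCCCCc1cn([C@@H]2O[C@@H]3CO[PH](O)(O)O[C@H]3[C@H]2O)c(=O)nc1N` — in a functional assay on L1210 cells (Mus musculus) for cytotoxicity (a higher number here means a weaker inhibitor, a lower number a stronger inhibitor), compound 1 gives only the assay limit > 200 ug/mL.
compound 2 `CCCc1cn([C@@H]2O[C@@H]3CO[PH](O)(O)O[C@H]3[C@H]2O)c(=O)nc1N` — in this assay compound 2 gives only the limit > 200 ug/mL.
compound 3 `CCc1cn([C@@H]2O[C@@H]3COP(=O)(O)O[C@H]3[C@H]2O)c(=O)nc1N` — in this assay compound 3 gives only the limit > 200 ug/mL.

From compound 2 to compound 1 the change is ethyl in place of hydrogen on a saturated chain carbon, three bonds along the chain from an aromatic carbon. Its step that the two limits leave unreadable from compound 2 to compound 1 stays unreadable because both values sit at the limit of > 200 ug/mL in this assay, at which 3 of the 3 values shown sit.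

Compound 4 `CCCCc1cn([C@@H]2O[C@@H]3COP(=O)(O)O[C@H]3[C@H]2O)c(=O)nc1N` awaits measurement. It differs from compound 3 by ethyl in place of hydrogen on a saturated chain carbon, two bonds along the chain from an aromatic carbon. This is the same kind of change as from compound 2 to compound 1, but the place differs: two bonds along the chain from an aromatic carbon here, three bonds there. How the core of compound 3 differs from that of compound 2 is not broken down here.

Compound 4 is expected to sit at 300 ug/mL in this assay. Within the data shown here, the expected step that the limit leaves unreadable from compound 3 to compound 4 rests on compound 3 standing at its limit > 200 ug/mL and on the unreadable step that the two limits leave unreadable from compound 2 to compound 1, since every value so far sits at the limit of > 200 ug/mL in this assay, at which 3 of the 3 values shown sit.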

Compound 4, concentration for 50% inhibition: > 200 ug/mL
Compound 4 ended at the assay's limit; the forecaster's own chance of this, stated with the estimate: 85%; the middle value lies beyond the limit too.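

No step can be read from compound 3 to compound 4, since both stand at a limit rather than a number: the limit of > 200 ug/mL in this assay, at which 4 of the 4 values shown sit.

The compounds shown leave open how large the change from hydrogen to ethyl is on either core.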